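A few compounds are considered here, and "the series" means these few. Any claim that something is new, unique, unknown or untested is made for them only; others in the source may bear on it.

Compound 2 `COc1c(OCc2nc3ccccc3[nH]2)cc(O)c2c(=O)cc(-c3ccccc3)oc12` and compound 1 `CCCCNCCOc1c(O)cc(O)c2c(=O)cc(-c3ccccc3)oc12` share the same flavone-type core, where compound 1 has no result in a functional assay on A549 cells (Homo sapiens) for cytotoxicity, read by MTT assay, with a stated time of 48 h; on this read-out higher numbers stand for weaker inhibition and lower numbers for stronger inhibition ("not determined" (no result reported)). In this assay compound 2 returns only the limit > 100000 nM rather than a number, so it stands at the upper boundary of what was measured, as the limit of > 100000 nM in this assay, at which 1 of the 2 values shown sits, records. Compound 3 `COc1c(OCCCNCc2ccccc2)cc(O)c2c(=O)cc(-c3ccccc3)oc12` differs from compound 2 by 2-(benzylamino)ethyl in place of 1H-benzimidazol-2-yl on a saturated chain carbon bound to an oxygen on an aromatic ring. With no measured steps shown and compound 2 at a limit, the direction of an at least 2.5-fold lower number from compound 2 to compound 3 (0.39 log units; beyond the scatter) is expected to be uncertain, and compound 3 is estimated at 40000 nM, within 8000 nM to 200000 nM.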

Compound 3, half-maximal inhibitory concentration: 1570 nM
Estimate against measurement, compound 3: 25-fold (1.41 log units) above, and the stated range ends above it.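

In this assay, 2-(benzylamino)ethyl in place of 1H-benzimidazol-2-yl gives an at least 63-fold lower number from compound 2 to compound 3 (1.80 log units; beyond the scatter), so the group on this saturated chain carbon bound to an oxygen on an aromatic ring can strongly move the read-out. Compound 3 gives 1570 nM, the first single number among the compounds shown. The step is only a bound, since compound 2 stands at a limit: the limit of > 100000 nM in this assay, at which 1 of the 3 values shown sits.

Which part of 2-(benzylamino)ethyl accounts for the step remains open, as the change replaces the whole group at once. From the compounds shown here alone, how a simple dimethylamine, a carboxylic acid or a longer chain would read at this place also remains open.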